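Swapping an Amide Cap for a Sulfonamide on the Aniline

This account rests on a few compounds, and the source may have more. Where it says the series, first, only, none or still open, it means among the compounds named here.

Compound 1 `CC(C)(C)c1cc(NC(=O)Nc2ccc(Cl)cc2)n(-c2ccc(N)cc2)n1` gives 5.6 degrees C in an assay on isolated protein for inhibition of STE20-like serine/threonine-protein kinase (Homo sapiens), read by thermal shift assay, tested at 10 uM; on this read-out lower numbers stand for weaker stabilisation of the target and higher numbers for stronger stabilisation of the target against heat.
Compound 2 `CC(C)C(=O)Nc1ccc(-n2nc(C(C)(C)C)cc2NC(=O)Nc2ccc(Cl)cc2)cc1` gives 6.8 degrees C in this assay.

Of the two measured compounds, compound 2 stands highest; its nearest neighbour is compound 1, and the step of a number 1.2 degrees C higher from compound 1 to compound 2 (beyond the scatter) shows how much the isopropylcarbonyl cap on the aniline nitrogen adds.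

Compound 3 `CC(C)(C)c1cc(NC(=O)Nc2ccc(Cl)cc2)n(-c2ccc(NS(C)(=O)=O)cc2)n1` keeps the shared core and changes only that cap: methylsulfonyl in place of isopropylcarbonyl on a nitrogen on an aromatic ring. Among the measured compounds shown here, the one measured step, a number 1.2 degrees C higher from compound 1 to compound 2 (beyond the scatter), tells what capping the bare nitrogen is worth, but no measured pair compares one cap with another, so the difference between an isopropylcarbonyl and a methylsulfonyl cap is untested here. Since both caps occupy the same nitrogen, and the capped compound 2 sits a modest way above the uncapped compound 1, the expectation for compound 3 is a number near that of compound 2, with a step of a number 0.50 degrees C lower from compound 2 to compound 3 (within the scatter) that is expected to stay within the scatter. Compound 3 is therefore estimated at 6.3 degrees C, in a range from 5 degrees C to 7.6 degrees C.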

Compound 3, shift of the target's melting temperature: 7.3 degrees C
Beside the measured number, compound 3's estimate is 1.0 degrees C below it, within the range that was stated.
By their numbers in this assay, from the lowest: compound 1; then compounds 2 and 3 (each within the scatter of the next).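

In this assay, exchanging the isopropylcarbonyl cap for methylsulfonyl gives a number 0.50 degrees C higher from compound 2 to compound 3 (within the scatter), so the two caps cannot be told apart on this read-out, even though one is built on a carbonyl and the other on a sulfonyl. Placing methylsulfonyl on the bare nitrogen gives a number 1.7 degrees C higher from compound 1 to compound 3 (beyond the scatter), which makes it the second cap that clears the scatter over the uncapped compound, after the isopropylcarbonyl step of a number 1.2 degrees C higher from compound 1 to compound 2 (beyond the scatter). At this position, then, the gain from capping the nitrogen does not depend on one particular cap among the two shown, and nothing shown here explains why either cap adds stabilisation.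

The compounds shown leave open how other caps on this nitrogen would read, such as an acetyl group, a benzoyl group or a longer alkylsulfonyl chain. They also leave open whether a plain methyl group on the nitrogen, with no carbonyl or sulfonyl link, would stand above compound 1 as well.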